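The source may report more compounds than this note shows. Statements on the series, on what has been measured and on what is new or still open speak of the compounds shown alone.

Measured compounds:
Compound 1 `COC(=O)c1ccc(C)cc1OC(=O)COc1cc(O)c2c(=O)cc(-c3ccccc3)oc2c1` — 31100 nM
Compound 2 `COC(=O)c1c(C)cccc1OC(=O)COc1cc(O)c2c(=O)cc(-c3ccccc3)oc2c1` — 37200 nM
Compound 3 `COC(=O)c1cccc(Cl)c1OC(=O)COc1cc(O)c2c(=O)cc(-c3ccccc3)oc2c1` — 38700 nM

All three compounds share one core and were tested in a functional assay on cells (T-cell, Mus musculus, strain BALB/c) for inhibition, read by MTT assay, with a stated time of 72 h; on this read-out lower numbers stand for stronger inhibition and higher numbers for weaker inhibition. Compound 1 has the lowest of the three numbers, but every gap between the three is small: a 1.2-fold higher number from compound 1 to compound 2 (0.08 log units; within the scatter), a 1.2-fold higher number from compound 1 to compound 3 (0.09 log units; within the scatter), and a 1.0-fold higher number from compound 2 to compound 3 (0.02 log units; within the scatter). On these data the three aromatic groups on the oxygen next to the carbonyl group cannot be told apart.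

Compound 4 `COC(=O)c1cc(C)ccc1OC(=O)COc1cc(O)c2c(=O)cc(-c3ccccc3)oc2c1` has not yet been measured. It differs from compound 1 in a single place: a group of 11 heavy atoms (9 carbon, 2 oxygen; one six-membered aromatic ring of carbon only) in place of a group of 11 heavy atoms (9 carbon, 2 oxygen; one six-membered aromatic ring of carbon only), on an oxygen next to a carbonyl group. The group that enters and the group that leaves have the same atoms joined differently, so compound 4 is a rearranged form of compound 1 at that position.

The three measured steps all exchange one aromatic group for another on the same oxygen, and none of them moved beyond the scatter. The same kind of exchange is therefore expected to give no step beyond the scatter here: a 1.1-fold higher number from compound 1 to compound 4 (0.04 log units; within the scatter). For compound 4 in this assay the estimate is 34000 nM, expected to fall between 17000 nM and 70000 nM.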

Compound 4, half-maximal inhibitory concentration: 25700 nM
Beside the measured number, compound 4's estimate is 1.3-fold (0.12 log units) above it, and the stated range covers the measured number.
By their numbers in this assay, from the lowest: compounds 4, 1, 2 and 3 (each within the scatter of the next).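

In this assay, rearranging the same atoms within the group on the oxygen next to a carbonyl group gives a 1.2-fold lower number from compound 1 to compound 4 (0.08 log units; within the scatter), so this fourth arrangement also cannot be told apart from compound 1. The comparisons with the other two compounds agree, with a 1.4-fold lower number from compound 2 to compound 4 (0.16 log units; within the scatter) and a 1.5-fold lower number from compound 3 to compound 4 (0.18 log units; within the scatter), so even the widest gaps among the four compounds do not separate them. No measurement is available that could explain these small steps.

Going by these compounds, it remains open whether any change at this oxygen can move the number beyond the scatter, for example an aromatic group carrying an amine or a carboxylic acid, or a longer chain in place of the aromatic group. The compounds shown also leave open how changes elsewhere on the shared core would act.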